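From 3,3-dimethylbutyl to 1-methylbutyl on the shared core

This account rests on a few compounds, and the source may have more. Where it says the series, first, only, none or still open, it means among the compounds named here.

Measured in an ADME assay on Huh-7 cells (Homo sapiens) for cytotoxicity, with a stated time of 72 h; a higher number here means that more compound is tolerated, a lower number that less compound is tolerated:
Compound 1 `CC(C)CCn1nc(-c2cncs2)c(O)c(C2=NS(=O)(=O)c3cc(NS(C)(=O)=O)ccc3N2)c1=O`: > 33000 nM
Compound 2 `CS(=O)(=O)Nc1ccc2c(c1)S(=O)(=O)N=C(c1c(O)c(-c3ccsc3)nn(CCC3CC3)c1=O)N2`: > 1000 nM
Compound 3 `CC(C)(C)CCn1nc(-c2cccs2)c(O)c(C2=NS(=O)(=O)c3cc(NS(C)(=O)=O)ccc3N2)c1=O`: > 1000 nM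

None of these three entries is a number. Compound 1 gives > 33000 nM, which is a limit. Compound 2 gives > 1000 nM, which is also a limit. Compound 3 stands at the limit of > 1000 nM in this assay, at which 2 of the 3 values shown sit, so it has no number of its own.

Compound 4 `CCCC(C)n1nc(-c2cccs2)c(O)c(C2=NS(=O)(=O)c3cc(NS(C)(=O)=O)ccc3N2)c1=O` has not yet been measured. It carries 1-methylbutyl in place of 3,3-dimethylbutyl on an aromatic nitrogen. Among the compounds with values here, no step between measured compounds is available as a guide.

The expected change, a step that the limit leaves unreadable from compound 3 to compound 4, is counted from a limit, so it is a loose estimate in the direction of more compound tolerated. This expectation rests on compound 1, whose limit of > 33000 nM is the highest shown. Compound 4 is also expected to return only a limit. For compound 4 the estimate is 10000 nM, with an expected range from 1500 nM to 40000 nM.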

Compound 4, half-maximal cytotoxic concentration: > 33000 nM
Compound 4: only a limit was reported (the forecaster's own chance of this, stated with the estimate: 85%); middle value at least 3.3-fold (0.51 log units) away from the limit.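

Compound 3 and compound 4 each return only a limit, and the step between them cannot be read. The compounds shown give no number of their own, leaving open whether 1-methylbutyl and 3,3-dimethylbutyl differ at all in this assay.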